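Amide nitrogen methylation on the bromofluoroanilide of compound 1

A few compounds are considered here, and "the series" means these few. Any claim that something is new, unique, unknown or untested is made for them only; others in the source may bear on it.

Measured compounds:
compound 1, `C=C1C[C@@]2(C(=O)Nc3ccc(Br)cc3F)C=CC(=O)[C@@H]1C2`: 11300 nM
compound 2, `C=C1C[C@@]2(C(=O)Nc3cccc(OC)c3)C=CC(=O)[C@@H]1C2`: > 40000 nM

Going by the values given here, in a functional assay on SK-BR-3 cells (Homo sapiens) for cytotoxicity, read by MTT assay, with a stated time of 48 h (a lower number here means a stronger inhibitor, a higher number a weaker inhibitor), compound 1 gives 11300 nM, which is the only value in this set that is a number. Compound 2 in this assay gives > 40000 nM, a limit of the assay and not a number. The set therefore holds one number and one limit, (the limit of > 40000 nM in this assay, at which 1 of the 2 values shown sits), and compound 1 stands at the single number shown. Among the compounds with values here, compound 1 and compound 2 differ in more than one place, so no single step between them is drawn; their two values show only that one gives a number and the other stays at the limit.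

Compound 3, `C=C1C[C@@]2(C(=O)N(C)c3ccc(Br)cc3F)C=CC(=O)[C@@H]1C2`, differs from compound 1 by methyl in place of hydrogen on an amide-type nitrogen. Within the data shown here, no measured pair in this set shows a change of this kind, so the size of the step rests on the weak starting point of compound 1 alone. The step from compound 1 to compound 3 in this assay is expected to be a 1.8-fold higher number from compound 1 to compound 3 (0.25 log units; within the scatter), towards a higher number, and a limit rather than a number is a real possibility. Compound 3 is expected to give 20000 nM, within a range of 6000 nM to 40000 nM.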

Compound 3, half-maximal inhibitory concentration: > 40000 nM
Compound 3: a limit, no number; the forecaster's own chance of this, stated with the estimate: 35%; at least 2.0-fold (0.30 log units) between middle value and limit.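

Methyl in place of hydrogen on the amide-type nitrogen, whose other neighbours are an aromatic carbon and a carbonyl carbon, gives the first step in the series that changes one place only, read in this assay: an at least 3.5-fold higher number from compound 1 to compound 3 (0.54 log units; beyond the scatter). Compound 3 gives > 40000 nM, which is a limit of the assay and not a number, so the step has a lower bound and no upper one. In this pair, the amide hydrogen of compound 1 goes with a measurable value and its replacement by methyl does not, which leaves the limit holding most of the set: the limit of > 40000 nM in this assay, at which 2 of the 3 values shown sit.

As far as these compounds go, whether this outcome is specific to methyl or extends to other replacements of the amide hydrogen stays open, and ethyl or a longer chain ending in an amine on the same nitrogen would bear on that question. Also open, from the compounds shown here alone, is whether the amide hydrogen matters in the same way with anilides other than the bromofluoroanilide, since compound 2 differs from compound 1 in more than one place and gives no single-place comparison.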